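The source may hold more compounds than are shown below. What is called first, only, known or untested is meant among the compounds shown, and "the series" means these compounds.

Measured in a toxicity assay on HepG2 cells (Homo sapiens) for inhibition, read by resazurin assay, with a stated time of 24 h; a lower number here means that less compound is tolerated, a higher number that more compound is tolerated:
- Compound 1 `CN(C)C(=O)c1ncc([N+](=O)[O-])n1C`: > 100000 nM
- Compound 2 `CNC(=O)c1nc([N+](=O)[O-])cn1Cc1ccc(OC(F)(F)F)cc1`: > 100000 nM

Both entries are limits of the assay and not numbers. Compound 2 stands at the limit of > 100000 nM in this assay, at which 2 of the 2 values shown sit. The measured data therefore give no exact value for compound 2, and they show no cytotoxic concentration for either compound.

Compound 3 `O=C(NO)c1nc([N+](=O)[O-])cn1Cc1ccc(OC(F)(F)F)cc1` keeps the rest of compound 2 but carries hydroxy in place of methyl on an amide-type nitrogen, a change of methylcarbamoyl to hydroxycarbamoyl: hydroxy in place of methyl on an amide-type nitrogen.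

Among the compounds with values here, no two measured compounds differ in just one place, so no measured step shows how large such a change might be. The expectation here is a modest move in this assay towards less compound being tolerated, though the result may well stay at the limit, with no visible change. The starting point is high, as compound 2 reads > 100000 nM. The expected size of the change is an at least 1.6-fold lower number from compound 2 to compound 3 (0.22 log units; that floor lies within the scatter). For compound 3 the estimated value is 60000 nM, with an expected range from 15000 nM to 100000 nM.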

Compound 3, half-maximal cytotoxic concentration: > 100000 nM
Compound 3: only a limit was reported; the forecaster's own chance of this, stated with the estimate: 55%; middle value at least 1.6-fold (0.22 log units) away from the limit.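

In this assay compound 3 gives > 100000 nM as a limit of the assay and not a number. Compound 2 also stands at a limit, and no step can be read from compound 2 to compound 3. Still open, as far as these compounds go, is whether hydroxy in place of methyl on an amide-type nitrogen changes the tolerated concentration at all.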